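A few compounds are considered here, and "the series" means these few. Any claim that something is new, unique, unknown or untested is made for them only; others in the source may bear on it.

Compound 1 `O[C@@H](c1ccccc1)[C@H]1CO[C@H](c2ccccc2)[C@@H](C/C=C/c2ccncc2)C1` is the starting point of this account. In a functional assay on HL-60 cells (Homo sapiens) for cytotoxicity, read by WST assay, with a stated time of 48 h (on this read-out lower numbers stand for stronger inhibition and higher numbers for weaker inhibition), compound 1 gives only a limit, > 100000 nM, and not a number. Compound 1 thus stands at the limit of > 100000 nM in this assay, at which 1 of the 2 values shown sits. Compound 2 `O=[N+]([O-])c1ccc(/C=C/C[C@H]2C[C@@H]([C@@H](O)c3ccccc3)CO[C@@H]2c2ccccc2)cc1` differs from compound 1 in one place, and in this assay compound 2 gives 4880 nM. For the measured compounds named here, the step of an at least 20-fold lower number from compound 1 to compound 2 (1.31 log units; beyond the scatter) is the only measured step that bears on the change followed here, and it was large. Compound 3 `O=[N+]([O-])c1cccc(/C=C/C[C@H]2C[C@@H]([C@@H](O)c3ccccc3)CO[C@@H]2c2ccccc2)c1` has not yet been measured in this assay. It differs from compound 1 as follows: 3-nitrophenyl in place of pyridin-4-yl on a double-bonded chain carbon bound to a double-bonded chain carbon. Since the measured change to compound 2 also replaced pyridin-4-yl with a nitrophenyl group on a double-bonded chain carbon bound to a double-bonded chain carbon, and gave an at least 20-fold lower number from compound 1 to compound 2 (1.31 log units; beyond the scatter), a step of similar size and in the same direction is expected for the 3-nitrophenyl analogue. For compound 3 the expected step is an at least 12-fold lower number from compound 1 to compound 3 (1.09 log units; beyond the scatter). Compound 3 is therefore estimated at 8000 nM, with a range from 2000 nM to 40000 nM.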

Compound 3, half-maximal inhibitory concentration: 6350 nM
Compound 3: the middle estimate sits 1.3-fold (0.10 log units) above what was measured; the range from low to high includes it.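

The change away from pyridin-4-yl is not tied to 4-nitrophenyl: with 3-nitrophenyl on the same double-bonded chain carbon, this assay records an at least 15-fold lower number from compound 1 to compound 3 (1.19 log units; beyond the scatter) and so extends the earlier result to a second nitrophenyl group. Exchanging the 4-nitrophenyl group for 3-nitrophenyl gives a 1.3-fold higher number from compound 2 to compound 3 (0.11 log units; within the scatter) and the two groups therefore cannot be told apart in this assay on this evidence. From the compounds shown here alone, the true size of both steps away from pyridin-4-yl remains unknown, because compound 1 gives only a limit and not a number: the limit of > 100000 nM in this assay, at which 1 of the 3 values shown sits.

The compounds shown leave open whether the nitro group itself matters, since they do not tell how a plain phenyl ring, or a phenyl ring carrying a nitrile, an amine or a carboxylic acid in place of the nitro group, would read at this position. They also leave open whether a longer chain bearing the 3-nitrophenyl or 4-nitrophenyl group would keep numbers of this order on the shared core.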